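A few compounds are considered here, and "the series" means these few. Any claim that something is new, unique, unknown or untested is made for them only; others in the source may bear on it.

Compound 2 `CC/N=c1/c(C#N)c2n(c(=O)n1-c1ccccc1)CCC2` and compound 1 `C/N=c1/c(C#N)c2n(c(=O)n1-c1ccccc1)CCC2` share one core and differ only on the chain carbon bound to the double-bonded nitrogen. In a functional assay on the whole organism (strain albino) for inhibition, with Rattus norvegicus as the target, read by paw edema, with a stated time of 2 h, at a dose of 0.029 mmol/kg by the oral route (on this read-out higher numbers stand for more inhibition at the one dose given (going by the name of the read-out) and lower numbers for less inhibition), compound 1 gives 26.5% and compound 2 gives 23.2%; the two numbers lie within the scatter of each other. Compound 3 `N#Cc1c2n(c(=O)n(-c3ccccc3)/c1=N\CCO)CCC2` is unmeasured; it differs from compound 2 by hydroxy in place of hydrogen on a saturated chain carbon, two bonds along the chain from a double-bonded nitrogen. For the measured compounds named here, the only related step, a number 3.3 percentage points lower from compound 1 to compound 2 (within the scatter), was within the scatter, and no measured pair carries a hydroxy, so no step beyond the scatter is expected: a number 0.8 percentage points higher from compound 2 to compound 3 (within the scatter). Compound 3 is estimated at 24%, between 10% and 38%.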

Compound 3, a percentage reported as inhibition, in the whole organism at one dose (the size of the read-out at that dose, not a potency): 22.3%
The estimate for compound 3 lay 1.7 percentage points above the measured number; the measured number falls inside the stated range.
By their numbers in this assay, from the lowest: compounds 3, 2 and 1 (each within the scatter of the next).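

Hydroxy on a saturated chain carbon, two bonds along the chain from a double-bonded nitrogen, gives a number 0.9 percentage points lower from compound 2 to compound 3 (within the scatter) in this assay and so brings a hydrogen-bond donor to the chain with no step beyond the scatter. Hydroxymethyl in place of hydrogen on the chain carbon bound to that nitrogen gives a number 4.2 percentage points lower from compound 1 to compound 3 (within the scatter) as well. Nothing available explains these results. As far as these compounds go, whether an amine, a carboxylic acid or a longer chain at this position would give a step beyond the scatter remains open.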